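The source may hold more compounds than are shown below. What is called first, only, known or untested is meant among the compounds shown, and "the series" means these compounds.

Compound 1 `CCCCCn1nc(C(=O)N[C@H]2COc3ccccc3N(C)C2=S)nc1Cc1ccccc1` gives only a limit in a toxicity assay on HT-29 cells (Homo sapiens) for cytotoxicity; a lower number here means that less compound is tolerated, a higher number that more compound is tolerated: > 100000 nM.
Compound 2 `CC(C)n1nc(C(=O)N[C@H]2COc3ccccc3N(C)C2=S)nc1Cc1ccccc1` likewise gives only a limit in this assay: > 100000 nM.
Compound 3 `CN1C(=S)[C@@H](NC(=O)c2nc(Cc3ccccc3)n(CCCF)n2)COc2ccccc21` also gives only a limit in this assay: > 100000 nM.

All three measured compounds share one core and differ only in the group carried on an aromatic nitrogen. Compound 2 stands at the same limit as the two others, so none of the three values shown is a true number. The steps among them, a step that the two limits leave unreadable from compound 1 to compound 2, a step that the two limits leave unreadable from compound 1 to compound 3 and a step that the two limits leave unreadable from compound 2 to compound 3, cannot be sized, because every value involved sits at the limit of > 100000 nM in this assay, at which 3 of the 3 values shown sit.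

Compound 4 `CN1C(=S)[C@@H](NC(=O)c2nc(Cc3ccccc3)n(C3CCNC3)n2)COc2ccccc21` is the next compound. It differs from compound 2 in one place: pyrrolidin-3-yl in place of isopropyl on an aromatic nitrogen. For the measured compounds named here, no measured step offers a readable size, so no direction for this change can be drawn from the three measured compounds in this assay.

For compound 4 the expectation is therefore a value again at or near the limit, estimated at 100000 nM with a range from 30000 nM to 300000 nM. The estimated step of a number no higher from compound 2 to compound 4 (the limit leaves the size open) is expected to lie within the scatter.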

Compound 4, half-maximal cytotoxic concentration: > 100000 nM
Compound 4: a limit, no number (the forecaster's own chance of this, stated with the estimate: 80%); the middle value sits exactly at the limit.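

Compound 4 gives only a limit in this assay and no number, so none of its steps to compound 1, compound 2 or compound 3 can be read, because all four compounds share that limit: the limit of > 100000 nM in this assay, at which 4 of the 4 values shown sit.

The compounds shown leave open what concentration of any of them would harm these cells, and whether the group on the aromatic nitrogen changes it.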